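Changing the Aryl Ether of Compound 2

A few compounds are considered here, and "the series" means these few. Any claim that something is new, unique, unknown or untested is made for them only; others in the source may bear on it.

Measured compounds:
compound 1 `COc1ccc(Oc2ccc3c(NCCCNCc4cccc(OC)c4O)ccnc3c2)cc1` with 14500 nM
compound 2 `COc1ccc(Oc2ccc3c(NCCCNCc4ccco4)ccnc3c2)cc1` with 14500 nM

In a physicochemical assay for solubility, with a stated time of 18 h, at pH 7.4 (a higher number here means a more soluble compound, a lower number a less soluble compound), compound 1 gives 14500 nM, and compound 2 gives 14500 nM. The one measured step, no change at the digits printed from compound 1 to compound 2 (within the scatter), shows that swapping the group on the saturated chain carbon bound to an amine nitrogen left the read-out where it was, so compound 2 stands level with compound 1 at the digits shown.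

Compound 3 `CN(C)c1cccc(Oc2ccc3c(NCCCNCc4ccco4)ccnc3c2)c1` is not yet measured. It differs from compound 2 by 3-(dimethylamino)phenyl in place of 4-methoxyphenyl on an oxygen on an aromatic ring. Going by the values given here, this is a different part of the shared core from the one altered between compound 1 and compound 2, and the step of no change at the digits printed from compound 1 to compound 2 (within the scatter) therefore says nothing direct about it. Among the compounds with values here, no measured pair in this set changes the aryl ether, so there is no basis for expecting a shift in either direction beyond the scatter.

On that footing, compound 3 is expected to give about 14500 nM in this assay, within 5000 nM to 40000 nM. The expected step is no change at the digits printed from compound 2 to compound 3 (within the scatter), carrying a wide range because only the unrelated step no change at the digits printed from compound 1 to compound 2 (within the scatter) is known.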

Compound 3, solubility: 14500 nM
For compound 3 middle estimate and measured number coincide at the digits printed, within the range that was stated.
By their numbers in this assay, from the lowest: compounds 1, 2 and 3 (each within the scatter of the next).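

In this assay, the aryl ether now has a measured step of its own: replacing 4-methoxyphenyl with 3-(dimethylamino)phenyl on an oxygen on an aromatic ring gives no change at the digits printed from compound 2 to compound 3 (within the scatter). Going by these compounds alone, the earlier step reached only the group on the saturated chain carbon bound to an amine nitrogen, so this is the first reading at this position, and it shows that this particular exchange of one substituted phenyl for another, with a nitrogen-bearing group entering and an oxygen-bearing group leaving, does not separate the two compounds in this read-out. Nothing in the data shown offers an account of this result.

Because the substituent and its ring position differ together in this exchange, the compounds shown do not separate the two, and 3-methoxyphenyl or 4-(dimethylamino)phenyl on the same oxygen would be needed to do so. They also leave open whether the level reading would hold for a quite different group there, such as a carboxylic acid on the phenyl ring or a simple alkyl chain in place of the phenyl ring.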